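A few compounds are considered here, and "the series" means these few. Any claim that something is new, unique, unknown or untested is made for them only; others in the source may bear on it.

Working notes on the series. All compounds share one core and differ only in the group on a saturated chain carbon bound to two saturated chain carbons and a saturated ring carbon. Compound 1 `Cc1ccc(C#N)c(OC(C)(C)C2OCC(C/C=C\CCC(=O)O)C(c3cccnc3)O2)c1` gives 50 nM in an assay for inhibition of Thromboxane-A synthase (Homo sapiens), using microsomes; a higher number here means a weaker inhibitor, a lower number a stronger inhibitor. Compound 2 `CC(C)(Oc1ccccc1F)C1OCC(C/C=C\CCC(=O)O)C(c2cccnc2)O1` gives 45 nM in this assay, and compound 3 `CC(C)(Sc1ccccc1)C1OCC(C/C=C\CCC(=O)O)C(c2cccnc2)O1` gives 40 nM in this assay. Compound 3 sits within the scatter of both neighbours: the step of a 1.1-fold lower number from compound 2 to compound 3 (0.05 log units; within the scatter) and the step of a 1.3-fold lower number from compound 1 to compound 3 (0.10 log units; within the scatter) are inside the usual spread, as is a 1.1-fold lower number from compound 1 to compound 2 (0.05 log units; within the scatter).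

Compound 4 `CC(C)(C1OCC(C/C=C\CCC(=O)O)C(c2cccnc2)O1)S(=O)(=O)c1ccccc1` is not yet measured. The change from compound 3 is phenylsulfonyl in place of phenylsulfanyl on a saturated chain carbon bound to two saturated chain carbons and a saturated ring carbon. None of the three measured steps touches this kind of change; each of them swaps one aryl group for another on the same chain carbon, and all three left the number unmoved beyond scatter. Within the data shown here, nothing in the data shows what the phenylsulfonyl group does here, so the comparison with compound 3 rests on no precedent. In the absence of one, the expected step of a 1.8-fold higher number from compound 3 to compound 4 (0.24 log units; within the scatter) in this assay is small and is held with a wide range. For compound 4 the estimate in this assay is 70 nM, between 25 nM and 250 nM.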

Compound 4, half-maximal inhibitory concentration: 40 nM
Estimate against measurement, compound 4: 1.8-fold (0.24 log units) above; the range from low to high includes it.
By their numbers in this assay, from the lowest: compounds 3, 4, 2 and 1 (each within the scatter of the next).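

In this assay the swap of phenylsulfanyl for phenylsulfonyl gives no change at the digits printed from compound 3 to compound 4 (within the scatter) on this saturated chain carbon, so this position also accommodates a change that leaves the aromatic ring in place and adds the 2 double bonds outside aromatic rings and the second hydrogen-bond acceptor counted for the entering group. Against the other two groups the phenylsulfonyl compound gives a 1.1-fold lower number from compound 2 to compound 4 (0.05 log units; within the scatter) and a 1.3-fold lower number from compound 1 to compound 4 (0.10 log units; within the scatter) in this assay and so joins them: all four groups on this carbon, each with one six-membered aromatic ring of carbon only, now lie within the scatter of one another. No supporting measurement bears on why this number holds.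

The compounds shown leave open whether this flat response extends to a group on this carbon without an aromatic ring, such as a methoxy, a cyclohexyl, an amine or a carboxylic acid. They also leave open where a phenylsulfinyl group or a longer chain between the sulfur and the phenyl ring would fall in this assay on this shared core.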